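Working notes: an aminoalkyl chain on the shared core

A few compounds are considered here, and "the series" means these few. Any claim that something is new, unique, unknown or untested is made for them only; others in the source may bear on it.

Values from a functional assay on HCT-116 cells (Homo sapiens) for cytotoxicity, read by MTT assay, with a stated time of 72 h (a lower number here means a stronger inhibitor, a higher number a weaker inhibitor), follow
compound 1 `Nc1ccc(Nc2c(C(=O)NCc3ccc(F)cc3)nc(Br)c3cccnc23)cc1` gives 10000 nM
compound 2 `COC(=O)CNc1c(C(=O)NCc2ccc(F)cc2)nc(Br)c2cccnc12` gives > 10000 nM

Compound 2 stands at > 10000 nM in this assay as a limit and not as a number. Going by the values given here, the series so far shows the limit of > 10000 nM in this assay, at which 1 of the 2 values shown sits, as its only such reading. In compound 3 `NCCCCCCNc1c(C(=O)NCc2ccc(F)cc2)nc(Br)c2cccnc12` a 5-aminopentyl takes the place of the methoxycarbonyl on a saturated chain carbon bound to a nitrogen on an aromatic ring, counted as 5-aminopentyl in place of methoxycarbonyl on a saturated chain carbon bound to a nitrogen on an aromatic ring in full. Among the compounds with values here, the only measured step is a number no lower from compound 1 to compound 2 (the limit leaves the size open) and it gives no size to carry over, since it swaps other groups. Within the data shown here, the expectation therefore rests on compound 1 at 10000 nM as the one firm number. A modest move towards lower numbers is expected, and another reading at the limit remains quite possible. The estimated change is an at least 1.6-fold lower number from compound 2 to compound 3 (0.22 log units; that floor lies within the scatter) on this reasoning. For compound 3 the expected value is 6000 nM with an estimated range of 1500 nM to 20000 nM in this assay here.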

Compound 3, half-maximal inhibitory concentration: 7000 nM
For compound 3 the middle estimate is 1.2-fold (0.07 log units) below the measured one; low and high end bracket the measured number.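

In this assay, from the compounds shown here alone, 5-aminopentyl in place of methoxycarbonyl on a saturated chain carbon bound to a nitrogen on an aromatic ring gives an at least 1.4-fold lower number from compound 2 to compound 3 (0.15 log units; that floor lies within the scatter), so a saturated chain at this place can return a firm number, while the size of the step stays open. Going by these compounds alone, compound 2 at > 10000 nM is a limit and not a number, and it remains the only such reading: the limit of > 10000 nM in this assay, at which 1 of the 3 values shown sits. Set against the aromatic group, 6-aminohexyl gives a 1.4-fold lower number from compound 1 to compound 3 (0.15 log units; within the scatter), so in this assay the two groups on this nitrogen cannot be told apart.

The compounds shown do not separate the amine from the chain that carries it, and a plain hexyl chain with no amine, a shorter or longer aminoalkyl chain, or a carboxylic acid in place of the methyl ester would each bear on that question. Going by these compounds, compound 1 gives 10000 nM, and whether any group at this place can move the number by more than the scatter is also open.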